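Three analogues near the floor and a methoxyphenyl newcomer

The compounds below may be only part of what the source reports. "The series", "measured", "known", "first", "only" and "open" are said of these compounds alone.

Measured so far:
compound 1, `CC(C)(C)c1csc(N)c1C(=O)c1ccc(Cl)cc1`: 1%
compound 2, `CC(C)(C)Cc1c(-c2cccnc2)sc(N)c1C(=O)c1ccc(Cl)cc1`: 1%
compound 3, `CC(C)(C)Cc1c(-c2ccc(F)cc2)sc(N)c1C(=O)c1ccc(Cl)cc1`: 1%

In an assay on CHO cells for displacement of a labelled ligand from adenosine receptor A1 (Homo sapiens), read by scintillation counting, tested at 10 uM (on this read-out higher numbers stand for more inhibition at the one concentration tested (going by the name of the read-out) and lower numbers for less inhibition), compound 1 gives 1%, compound 2 gives 1% and compound 3 gives 1%. Among the compounds with values here, the only single-point step among them, no change at the digits printed from compound 2 to compound 3 (within the scatter), shows that exchanging one six-membered aromatic group for another on the same aromatic carbon left the read-out where it was. Compound 3 therefore stands level with compound 1 and compound 2 at the digits shown; none of the three can be called the stronger or weaker.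

Compound 4, `COc1cccc(-c2sc(N)c(C(=O)c3ccc(Cl)cc3)c2CC(C)(C)C)c1`, is the next point along the same line of exchange: 3-methoxyphenyl in place of 4-fluorophenyl on an aromatic carbon. Within the data shown here, the one measured step that bears on this kind of change, no change at the digits printed from compound 2 to compound 3 (within the scatter), was flat within the scatter, and no other measurement speaks to it. The expected step of a number 1 percentage points higher from compound 3 to compound 4 (within the scatter) is accordingly none beyond the scatter. Compound 4 is estimated to give 2%, with a range from -6% to 12%.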

Compound 4, a percentage reported as inhibition, at one concentration (the size of the read-out at that concentration, not a potency): 1%
Beside the measured number, compound 4's estimate is 1 percentage points above it; measured number inside the range.
By their numbers in this assay, from the lowest: compounds 1, 2, 3 and 4 (each within the scatter of the next).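

At this carbon, next to the ring sulfur, the exchange of 4-fluorophenyl for 3-methoxyphenyl in this assay gives no change at the digits printed from compound 3 to compound 4 (within the scatter) and so extends the flat picture to a ring with a substituent in a different place, one that brings an oxygen and a hydrogen-bond acceptor. The exchange of pyridin-3-yl for 3-methoxyphenyl gives no change at the digits printed from compound 2 to compound 4 (within the scatter) and closes the set: all three aryl groups at this position now read alike, and none can be ranked above another. No information is available that would explain this flat result.

All three readings lie so low that they leave open whether this position can influence the read-out at all. From the compounds shown here alone, whether an aminomethyl group or a carboxylic acid here would change the picture remains unknown, as does whether the same flatness would hold with a shorter chain in place of the neopentyl group.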